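Fluoro to Chloro on a Pendant Phenyl Ring

This account rests on a few compounds, and the source may have more. Where it says the series, first, only, none or still open, it means among the compounds named here.

Measured in a functional assay on MDA-MB-231 cells (Homo sapiens) for inhibition, read by MTT assay, with a stated time of 48 h; on this read-out lower numbers stand for stronger inhibition and higher numbers for weaker inhibition:
compound 1 `Fc1ccc(-n2c(S)nnc2Sc2nnc(-c3ccccc3)n2-c2ccccc2)cc1`: 29700 nM
compound 2 `Sc1nnc(Sc2nnc(-c3ccccc3)n2-c2ccccc2)n1-c1ccccc1`: 34600 nM
compound 3 `Sc1nnc(CSc2nnc(-c3ccccc3)n2-c2ccccc2)n1-c1ccc(Cl)cc1`: 50300 nM

On the numbers shown, compound 1 stands at the low end, yet compound 2 and compound 3 both lie within the scatter of it: a 1.2-fold higher number from compound 1 to compound 2 (0.07 log units; within the scatter), and the gap to compound 3 is likewise within the scatter. Compound 4 `Sc1nnc(Sc2nnc(-c3ccccc3)n2-c2ccccc2)n1-c1ccc(Cl)cc1` differs from compound 1 by chloro in place of fluoro on an aromatic carbon. For the measured compounds named here, only one measured step touches that position, the change from compound 1 to compound 2, and it stayed within the scatter; compound 3 carries a chloro group but differs in a second place as well, so it bears only loosely. For compound 4 the expected step is a 1.0-fold higher number from compound 1 to compound 4 (0.00 log units; within the scatter), nothing beyond the scatter. The estimate for compound 4 is 30000 nM, ranging from 15000 nM to 60000 nM.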

Compound 4, half-maximal inhibitory concentration: 49700 nM
The estimate for compound 4 lay 1.7-fold (0.22 log units) below the measured number, and the stated range covers the measured number.
By their numbers in this assay, from the lowest: compounds 1, 2, 4 and 3 (each within the scatter of the next).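

In this assay the same core now carries fluoro, hydrogen or chloro at this position, on an aromatic carbon para to a large group, and the change to chloro gives a 1.7-fold higher number from compound 1 to compound 4 (0.22 log units; within the scatter) and a 1.4-fold higher number from compound 2 to compound 4 (0.16 log units; within the scatter). On these numbers, none of the three groups separates from the others at this position. Nothing available bears on the reason for this result. From the compounds shown here alone, whether an amine, a carboxylic acid or a longer chain here would move the number beyond the scatter remains open.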